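The compounds below may be only part of what the source reports. "The series", "measured", "known", "first", "only" and "open" are said of these compounds alone.

Measured so far in an ADME assay on MDBK cells (Bos taurus) for cytotoxicity; a higher number here means that more compound is tolerated, a lower number that less compound is tolerated:
- Compound 1 `Fc1cccc(Cn2ccc3nc(-c4ccccc4)nc-3c2)c1`: > 100000 nM
- Compound 2 `Brc1cccc(Cn2ccc3nc(-c4ccccc4)nc-3c2)c1`: 85000 nM
- Compound 3 `CCC(CC)Cn1ccc2nc(-c3ccccc3)nc-2c1`: > 100000 nM

Compound 3 gives > 100000 nM, which is a limit of the assay and not a number. The same limit applies to compound 1, as the limit of > 100000 nM in this assay, at which 2 of the 3 values shown sit, records, so only compound 2 has a true number here.

Compound 4 `Clc1ccc(Cn2ccc3nc(-c4ccccc4)nc-3c2)s1` has 5-chlorothiophen-2-yl in place of pentan-3-yl on a saturated chain carbon bound to an aromatic nitrogen.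

The closest guide is the step of an at least 1.1-fold higher number from compound 2 to compound 3 (0.07 log units; that floor lies within the scatter), where an aromatic group bearing a halogen also gives way to pentan-3-yl. That floor is small, and the step of an at least 1.1-fold lower number from compound 1 to compound 2 (0.07 log units; that floor lies within the scatter) is small as well. The step that the two limits leave unreadable from compound 1 to compound 3 cannot be read at all. Going back to a halogen-bearing aromatic group, a small fall in this assay is expected, possibly none beyond the scatter.

The expected step is an at least 1.2-fold lower number from compound 3 to compound 4 (0.09 log units; that floor lies within the scatter).

For compound 4, the estimated value is 80000 nM, with an expected range from 35000 nM to 100000 nM.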

Compound 4, half-maximal cytotoxic concentration: > 100000 nM
Compound 4: no number, only a limit (the forecaster's own chance of this, stated with the estimate: 45%); middle value at least 1.2-fold (0.09 log units) away from the limit.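

In this assay compound 4 gives > 100000 nM, which is a limit of the assay and not a number. For the compounds shown here, the 5-chlorothiophen-2-yl group on this saturated chain carbon bound to an aromatic nitrogen thus shows that a five-membered aromatic ring can take the place of a benzene ring or of pentan-3-yl with no measurable fall in this read-out, and the only step that can be read is an at least 1.1-fold higher number from compound 2 to compound 4 (0.07 log units; that floor lies within the scatter), while the steps to compound 1 and compound 3 cannot be read. Most of the set now sits at a single limit: the limit of > 100000 nM in this assay, at which 3 of the 4 values shown sit.

Going by these compounds, it remains open whether any group at this place gives a fall in this assay that clearly exceeds the scatter, and how far compound 1, compound 3 and compound 4 lie past the limit. On these data alone, how an amine or a carboxylic acid at this place would read also remains open.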